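The source may report more compounds than this note shows. Statements on the series, on what has been measured and on what is new or still open speak of the compounds shown alone.

Measured so far in a functional assay on HT-29 cells (Homo sapiens) for cytotoxicity, read by MTT assay, with a stated time of 48 h; a higher number here means a weaker inhibitor, a lower number a stronger inhibitor:
Compound 1 `O=C(/C=C(/C=C/c1ccc(O)cc1)NCCCO)/C=C/c1ccc(O)cc1`: 58900 nM
Compound 2 `COCCNC(=C\C(=O)/C=C/c1ccc(O)cc1)/C=C/c1ccc(O)cc1`: 57400 nM

Only these two numbers are available, and they cannot be told apart. Going by the values given here, the single measured step is a 1.0-fold lower number from compound 1 to compound 2 (0.01 log units; within the scatter). Among the compounds with values here, compound 2 therefore stands level with the only other measured compound, with neither ahead of the other.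

The next compound, compound 3 `O=C(/C=C(/C=C/c1ccc(O)cc1)NCCO)/C=C/c1ccc(O)cc1`, differs from compound 2 by one change: hydrogen in place of methyl on an oxygen on a saturated carbon. This places hydrogen in place of methyl on an oxygen on a saturated carbon, turning 2-methoxyethyl into 2-hydroxyethyl.

Within the data shown here, no measured step isolates this exact change, so the evidence is indirect. The nearest guide also involves methoxy on the chain, in place of hydroxymethyl. Among the measured compounds shown here, a shift beyond the scatter is not expected, because a 1.0-fold lower number from compound 1 to compound 2 (0.01 log units; within the scatter) is the only measured step on this chain and it shows no separation. The estimated step is a 1.0-fold higher number from compound 2 to compound 3 (0.00 log units; within the scatter). In this assay, compound 3 is expected to give 58000 nM, with an estimated range of 30000 nM to 110000 nM.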

Compound 3, half-maximal inhibitory concentration: 66200 nM
Estimate against measurement, compound 3: 1.1-fold (0.06 log units) below; low and high end bracket the measured number.
By their numbers in this assay, from the lowest: compounds 2, 1 and 3 (each within the scatter of the next).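

In this assay, the oxygen at the end of this chain tolerates the loss of its methyl without any separation: hydrogen in place of methyl on an oxygen on a saturated carbon, which turns 2-methoxyethyl into 2-hydroxyethyl, gives a 1.2-fold higher number from compound 2 to compound 3 (0.06 log units; within the scatter). The second change at this position, hydroxy in place of hydroxymethyl on a saturated chain carbon, gives a 1.1-fold higher number from compound 1 to compound 3 (0.05 log units; within the scatter), so this too leaves the number unresolved from that of its partner. Taken together, the three compounds stand level, and neither the methoxy, the hydroxy nor the hydroxymethyl ending can be told apart from the others here; nothing further is available to explain this flat reading.

What the compounds leave open is whether a group of a different kind at this place, such as an amine, a carboxylic acid or a longer chain, would move the number beyond the scatter. Also open, as far as these compounds go, is how far changes elsewhere would shift it, as the rest of the shared core is identical in all three compounds.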